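This account rests on a few compounds, and the source may have more. Where it says the series, first, only, none or still open, it means among the compounds named here.

In a physicochemical assay for solubility, using the shake flask method, measured as thermodynamic solubility, with a stated time of 2 h, at pH 6.5 (a lower number here means a less soluble compound, a higher number a more soluble compound), compound 1 `OC[C@H]1O[C@H](Oc2ccc(-n3ccc4ccccc43)cc2Cl)[C@@H](O)[C@@H](O)[C@@H]1O` gives 31.5 ug/mL, whereas compound 2 `O=[N+]([O-])c1ccc2c(ccn2-c2ccc(O[C@H]3O[C@H](CO)[C@@H](O)[C@H](O)[C@@H]3O)c(Cl)c2)c1` gives 1.4 ug/mL. The two differ in one place, (hydrogen in place of nitro on an aromatic carbon), and that change made a 23-fold higher number from compound 2 to compound 1 (1.35 log units; beyond the scatter). Compound 3 `O=[N+]([O-])c1ccc2c(c1)CCN2c1ccc(O[C@H]2O[C@H](CO)[C@@H](O)[C@H](O)[C@@H]2O)c(Cl)c1` is built on another core, and the difference between the two cores is not broken down here. In this assay compound 3 gives 3.6 ug/mL, a number that stands between those of compound 2 and compound 1. Compound 4 `OC[C@H]1O[C@H](Oc2ccc(N3CCc4ccccc43)cc2Cl)[C@@H](O)[C@@H](O)[C@@H]1O` has not yet been measured. It differs from compound 3 by hydrogen in place of nitro on an aromatic carbon, the same change that separates compound 2 from compound 1. A step of comparable size is expected in this assay, namely a 14-fold higher number from compound 3 to compound 4 (1.14 log units; beyond the scatter). Within the data shown here, that expectation rests on a 23-fold higher number from compound 2 to compound 1 (1.35 log units; beyond the scatter), the only earlier instance of this change. Compound 4 is therefore estimated at 50 ug/mL. The likely range for compound 4 runs from 15 ug/mL to 150 ug/mL.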

Compound 4, solubility: 21 ug/mL
Estimate against measurement, compound 4: 2.4-fold (0.38 log units) above; low and high end bracket the measured number.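

On the second core, the nitro-to-hydrogen change again gave a higher number in this assay (a 5.8-fold higher number from compound 3 to compound 4 (0.77 log units; beyond the scatter)), in the same direction as on the first core (a 23-fold higher number from compound 2 to compound 1 (1.35 log units; beyond the scatter)). These two instances show that the direction carried over from one core to the other, but they do not establish a fixed size for the step or a rule for other cores. With hydrogen in place on both cores, the two compounds lie within the scatter of each other (a 1.5-fold lower number from compound 1 to compound 4 (0.18 log units; within the scatter)), and nothing shown here gives a reason for these results.

Only nitro and hydrogen appear at this place on the aromatic ring. From the compounds shown here alone, what an amine or a carboxylic acid there would give in this assay remains open.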